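A few compounds are considered here, and "the series" means these few. Any claim that something is new, unique, unknown or untested is made for them only; others in the source may bear on it.

an ADME assay on microsomes from liver (Rattus norvegicus) for metabolic stability, read by LC-MS, with a stated time of 30 min, tested at 0.1 uM (on this read-out higher numbers stand for a more stable compound and lower numbers for a less stable compound), tells how much of a compound survives a fixed incubation with liver microsomes, so a high number means slow breakdown. Two compounds have been run. Compound 1 `Fc1ccc(-c2nc3cnc(Nc4ccccn4)cc3[nH]2)cc1F` gives 48% in this assay. Compound 2 `FC(F)(F)c1ccc(Nc2cc3[nH]c(C4CCCC4)nc3cn2)nc1` gives 1% in this assay, the lower of the two numbers, and its gap to compound 1 lies beyond the scatter, so compound 2 is clearly the less stable of the pair. Compound 3 `FC(F)(F)c1ccc(Nc2cc3[nH]c([C@H]4CC[C@H](C(F)(F)F)CC4)nc3cn2)nc1` is not yet measured. It differs from compound 2 in one place: 4-(trifluoromethyl)cyclohexyl in place of cyclopentyl on an aromatic carbon. Among the measured compounds shown here, no measured pair shares this change, so the data give no guide to its effect. Because compound 2 already gives the low value 1%, the expected step of a number 7 percentage points higher from compound 2 to compound 3 (within the scatter) is small, upward if anything, and may stay within the scatter. Compound 3 is estimated at 8%, within a range from 1% to 30%.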

Compound 3, percent of the compound remaining: 64%
Compound 3: the middle estimate sits 56 percentage points below what was measured; the whole stated range lies below it.
By their numbers in this assay, from the lowest: compound 2; then compound 1; then compound 3.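

Swapping cyclopentyl for 4-(trifluoromethyl)cyclohexyl on the aromatic carbon between two ring nitrogen atoms gives a number 63 percentage points higher from compound 2 to compound 3 (beyond the scatter) in this assay while the rest of the molecule stays the same. This position therefore has a strong influence on this read-out, and a compound that almost entirely disappears during the incubation can be turned into one of which much survives through this single change. Nothing available explains why the number rises so sharply.

The change enlarges the ring and adds a trifluoromethyl group at once, so the compounds shown cannot say which of the two matters, and a plain cyclohexyl would help to separate them. Going by these compounds, whether a methyl group, an amine or a carboxylic acid in place of the trifluoromethyl would give a similar result also remains open.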